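The compounds below may be only part of what the source reports. "The series", "measured", "known", "first", "only" and "open" are said of these compounds alone.

Measured in an assay for binding affinity to Neuronal acetylcholine receptor; alpha4/beta2 (Rattus norvegicus); a higher number here means a weaker inhibitor, a lower number a stronger inhibitor:
- compound 1 `Clc1ccc2cc3c(cc2n1)C1CNCC3C1` gives 0.27 nM
- compound 2 `Cc1ccnc2cc3c(cc12)C1CNCC3C1` gives 1.8 nM
- compound 3 `CC(C)c1nc2cc3c(cc2o1)C1CNCC3C1` gives 7.6 nM

Compound 1 holds the lowest inhibition constant of the three; compound 2 is nearest and compound 3 furthest, both gaps beyond the scatter. No two of these compounds differ in one place, so no single step is measured.

Compound 4 `COc1ccc2cc3c(cc2n1)C1CNCC3C1` is not yet measured. It differs from compound 1 by methoxy in place of chloro on an aromatic carbon, a methoxy in place of chloro on an aromatic carbon. With no measured step of this kind in the set, the expectation is a moderate rise in the inhibition constant, i.e. a weaker inhibitor than compound 1, the step of a 7.4-fold higher number from compound 1 to compound 4 (0.87 log units; beyond the scatter) being an estimate. Compound 4 is expected to give about 2 nM in this assay, with a range of 0.4 nM to 10 nM.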

Compound 4, inhibition constant: 30 nM
Compound 4: middle estimate off by 15-fold (1.18 log units), on the low side; measured number above the stated range.
By their numbers in this assay, from the lowest: compound 1; then compound 2; then compound 3; then compound 4.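

At this position, on an aromatic carbon next to the ring nitrogen, methoxy in place of chloro gives a 110-fold higher number from compound 1 to compound 4 (2.05 log units; beyond the scatter) in this assay. This first single-place step in the series shows that affinity is highly sensitive to the group at this position, with chloro far ahead of methoxy. No available evidence bears on the origin of this step.

Going by these compounds, with only chloro and methoxy compared here, it remains open where a fluoro or an amine at this position would fall. On these data alone, whether the same change would have a comparable effect on another core also remains open.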